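A few compounds are considered here, and "the series" means these few. Any claim that something is new, unique, unknown or untested is made for them only; others in the source may bear on it.

In a functional assay on HT-29 cells (Homo sapiens) for inhibition, read by sulforhodamine B assay, with a stated time of 72 h (on this read-out higher numbers stand for weaker inhibition and lower numbers for stronger inhibition), compound 2 `CCSc1ccc(C2C(Oc3ccccc3)C(=O)N2c2cc(OC)c(OC)c(OC)c2)cc1` gives 632 nM, and compound 1 `CCOc1ccc(C2C(Oc3ccccc3)C(=O)N2c2cc(OC)c(OC)c(OC)c2)cc1` gives 388 nM; since the step of a 1.6-fold higher number from compound 1 to compound 2 (0.21 log units; within the scatter) lies within the scatter, the two compounds stand together on this read-out. Compound 3 `CCSc1ccc(C2C(O)C(=O)N2c2cc(OC)c(OC)c(OC)c2)cc1` differs from compound 2 by hydrogen in place of phenyl on an oxygen on a saturated carbon. For the measured compounds named here, no measured step touches this part of the molecule: the only step known, between compound 1 and compound 2, concerns the ethylsulfanyl and ethoxy groups, so it gives no guide here. Compound 3 is therefore estimated with wide uncertainty, at 1500 nM (range 300 nM to 8000 nM), a step of a 2.4-fold higher number from compound 2 to compound 3 (0.38 log units; beyond the scatter) expected toward a higher number.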

Compound 3, half-maximal inhibitory concentration: 12 nM
Beside the measured number, compound 3's estimate is 130-fold (2.10 log units) above it, outside the stated range (below it).
By their numbers in this assay, from the lowest: compound 3; then compounds 1 and 2 (each within the scatter of the next).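

In this assay, the change from phenoxy to hydroxy gives a 53-fold lower number from compound 2 to compound 3 (1.72 log units; beyond the scatter), so this position matters far more on this read-out than the ethoxy and ethylsulfanyl exchange, whose step stayed within the scatter. With ethylsulfanyl in place, the phenyl on this oxygen is not needed for strong inhibition. No evidence at hand accounts for the size of this step. The compounds shown leave open whether an amine or an acetoxy group at this place would match hydroxy, and whether the same step holds with ethoxy in place of ethylsulfanyl.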